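An Isobutyl Group on a Saturated Ring Carbon

This account rests on a few compounds, and the source may have more. Where it says the series, first, only, none or still open, it means among the compounds named here.

Compound 1 `Cc1ccc(S(=O)(=O)N2CCC(Br)CC2)cc1` was tested in a functional assay on SW1573 cells (Homo sapiens) for antiproliferative activity, read by sulforhodamine B assay, with a stated time of 48 h; a higher number here means a weaker inhibitor of growth, a lower number a stronger inhibitor of growth. In this assay compound 1 gives > 100000 nM, which is a limit of the assay rather than a number. Compound 2 `Cc1ccc(S(=O)(=O)N2CC[C@@H](Br)C[C@@H]2CC(C)C)cc1` carries the change isobutyl in place of hydrogen on a saturated ring carbon on the core of compound 1, and in this assay compound 2 gives 22000 nM. That change produced an at least 4.5-fold lower number from compound 1 to compound 2 (0.65 log units; beyond the scatter). Compound 3 `Cc1ccc(S(=O)(=O)N2CC=C(Br)CC2)cc1` has a different core; how the cores of compound 1 and compound 3 differ is not broken down here. In this assay compound 3 gives > 100000 nM, again a limit of the assay, matching (the limit of > 100000 nM in this assay, at which 2 of the 3 values shown sit). Within the data shown here, compound 4 `Cc1ccc(S(=O)(=O)N2CCC(Br)=CC2CC(C)C)cc1` relates to compound 3 through (isobutyl in place of hydrogen on a saturated ring carbon), the same change as the one from compound 1 to compound 2, at a place described in the same words. Because an at least 4.5-fold lower number from compound 1 to compound 2 (0.65 log units; beyond the scatter) followed that change before, the step from compound 3 to compound 4 is expected to be an at least 3.3-fold lower number from compound 3 to compound 4 (0.52 log units; beyond the scatter). Compound 4 is therefore estimated at 30000 nM, with a range from 10000 nM to 100000 nM, though the assay may again report only a limit.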

Compound 4, concentration for 50% growth inhibition: 26000 nM
Estimate against measurement, compound 4: 1.2-fold (0.06 log units) above; the measured number falls inside the stated range.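

In this assay compound 3 gives > 100000 nM, which is a limit of the assay and not a number. Isobutyl in place of hydrogen on a saturated ring carbon gave an at least 3.8-fold lower number from compound 3 to compound 4 (0.58 log units; beyond the scatter), so on both cores shown the change went with a lower number, and in this series its direction carried from one core to the other: the same change on two cores in this assay, an at least 4.5-fold lower number (0.65 log units; beyond the scatter) from compound 1 to compound 2 and an at least 3.8-fold lower number (0.58 log units; beyond the scatter) from compound 3 to compound 4; the limit leaves it open whether they differ What this does not show is the true size of either step or whether the two sizes match, since each step starts from a compound that sits at the limit: the limit of > 100000 nM in this assay, at which 2 of the 4 values shown sit.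

The compounds shown leave open whether a methyl group or a longer chain at the same place would go with a similar change. They also leave open whether the isobutyl change would carry over to a core with chloro in place of bromo.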